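One More Chain Carbon on the Diethylamino Side Chain

This account rests on a few compounds, and the source may have more. Where it says the series, first, only, none or still open, it means among the compounds named here.

In a functional assay on LNCaP cells (Homo sapiens) for antiproliferative activity, read by WST assay, with a stated time of 3 days (a higher number here means a weaker inhibitor, a lower number a stronger inhibitor), compound 1 (`CCCCOc1c(-c2cc(OC)c(OC)c(OC)c2)oc2ccccc2c1=O`) gives 8900 nM, compound 2 (`CCCCCCOc1c(-c2cc(OC)c(OC)c(OC)c2)oc2ccccc2c1=O`) gives 19600 nM and compound 3 (`CCN(CC)CCCOc1c(-c2cc(OC)c(OC)c(OC)c2)oc2ccccc2c1=O`) gives 37600 nM. Compound 3 lies among the higher numbers shown: the data give a 1.9-fold higher number from compound 2 to compound 3 (0.28 log units; within the scatter) and a 4.2-fold higher number from compound 1 to compound 3 (0.63 log units; beyond the scatter). Compound 4 (`CCN(CC)CCCCOc1c(-c2cc(OC)c(OC)c(OC)c2)oc2ccccc2c1=O`) differs by (diethylamino)methyl in place of diethylamino on a saturated chain carbon, three bonds along the chain from an oxygen on an aromatic ring, which reads as 3-(diethylamino)propyl to 4-(diethylamino)butyl. For the measured compounds named here, the nearest precedent for a longer chain is modest, a 2.2-fold higher number from compound 1 to compound 2 (0.34 log units; beyond the scatter), and it carries no diethylamino group. No step beyond the scatter is therefore expected in this assay, with at most a slight rise. The expected change is a 1.1-fold higher number from compound 3 to compound 4 (0.05 log units; within the scatter). The estimate for compound 4 is 42000 nM, with an expected range of 17000 nM to 90000 nM.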

Compound 4, half-maximal inhibitory concentration: 13500 nM
The estimate for compound 4 lay 3.1-fold (0.49 log units) above the measured number; measured number below the stated range.
By their numbers in this assay, from the lowest: compounds 1, 4, 2 and 3 (each within the scatter of the next, the first and the last beyond it).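

In this assay, one more chain carbon on the diethylamino side chain is not a silent change (a 2.8-fold lower number from compound 3 to compound 4 (0.44 log units; beyond the scatter)), and its direction is opposite to that of the longer plain chain (a 2.2-fold higher number from compound 1 to compound 2 (0.34 log units; beyond the scatter)). With the diethylamino group on the butyl chain, the number stands within the scatter of both plain chains (a 1.5-fold lower number from compound 2 to compound 4 (0.16 log units; within the scatter); a 1.5-fold higher number from compound 1 to compound 4 (0.18 log units; within the scatter)), so the diethylamino group does not set a higher number at every chain length. Nothing shown here explains this reversal.

As far as these compounds go, whether a 2-(diethylamino)ethyl chain or a longer amino chain would follow compound 3 or compound 4 remains open. So does the effect of a pyrrolidine or morpholine at the chain end.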